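The source may hold more compounds than are shown below. What is called first, only, known or untested is meant among the compounds shown, and "the series" means these compounds.

Working notes on the series. Compound 1 `Cc1cc(COc2cccc(Cl)c2)nc(-c2ccccn2)n1` and compound 2 `OC1CN(c2cc(COc3ccc(F)c(F)c3F)nc(-c3ccccn3)n2)C1` have both been run in a functional assay on cells for antagonist activity at Free fatty acid receptor 1 (Homo sapiens), read by TR-FRET and inositol phosphate accumulation, with a stated time of 2 h; on this read-out higher numbers stand for weaker inhibition and lower numbers for stronger inhibition. In this assay compound 1 gives 398 nM, and compound 2 gives 3160 nM. Among the compounds with values here, of the two numbers so far, compound 2 holds the higher one, and its distance from compound 1 lies beyond the usual scatter of repeated measurements.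

Compound 3 `CC1(COc2cc(COc3ccc(F)c(F)c3F)nc(-c3ccccn3)n2)COC1` is not yet measured in this assay. It differs from compound 2 in a single place: (3-methyloxetan-3-yl)methoxy in place of 3-hydroxyazetidin-1-yl on an aromatic carbon. The hydrogen-bond donor of the leaving group is lost, while the count of hydrogen-bond acceptors stays the same and the entering group is somewhat larger.

Within the data shown here, no measured pair shows this exchange, so its effect cannot be read from the numbers at hand. The step is therefore expected to be modest, a 1.3-fold lower number from compound 2 to compound 3 (0.10 log units; within the scatter), with no firm direction beyond the scatter. For compound 3 in this assay the estimate is 2500 nM, with a plausible range from 600 nM to 10000 nM.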

Compound 3, half-maximal inhibitory concentration: 79.4 nM
Beside the measured number, compound 3's estimate is 31-fold (1.50 log units) above it; measured number below the stated range.
By their numbers in this assay, from the lowest: compound 3; then compound 1; then compound 2.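

On this aromatic carbon, next to the ring nitrogen and meta to a pyridin-2-yl group, the exchange of 3-hydroxyazetidin-1-yl for (3-methyloxetan-3-yl)methoxy gives a 40-fold lower number from compound 2 to compound 3 (1.60 log units; beyond the scatter) in this assay and shows that the read-out responds strongly to the group at this position, which compound 1 and compound 2 could not show, as they differ in more than one place. The step combines several changes: the hydrogen-bond donor is lost, the group grows from 5 to 7 heavy atoms, and the four-membered ring stays but its hetero atom changes from nitrogen to oxygen, while the count of hydrogen-bond acceptors stays the same. Nothing at hand explains the size of this step.

The compounds shown leave open which of these changes carries the step, a question that 3-methoxyazetidin-1-yl or a plain methoxy group on the same carbon could help to separate. Also open, on these data alone, is how this position responds to a basic amine such as morpholine, a carboxylic acid, or a longer alkoxy chain.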